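Swapping the ring group on a lipid-linked compound

This account rests on a few compounds, and the source may have more. Where it says the series, first, only, none or still open, it means among the compounds named here.

Measured in an ADME assay on CCRF-CEM cells (Homo sapiens) for cytotoxicity; on this read-out lower numbers stand for higher toxicity in this test and higher numbers for lower toxicity in this test:
- compound 1 `CCCCCCCCCCCCCCCCC(OP(=O)(O)OC[C@@H]1C=C[C@H](n2cc(C)c(=O)[nH]c2=O)O1)C(=O)O`: 92600 nM
- compound 2 `CCCCCCCCCCCCCCCC(CC(=O)O)OP(=O)(O)OC[C@@H]1C=C[C@H](n2cc(C)c(=O)[nH]c2=O)O1`: > 198000 nM

Among the measured compounds shown here, compound 1 holds the only true number in this assay, 92600 nM. The entry for compound 2, > 198000 nM, is a limit of the assay and not a number.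

Compound 3 `CCCCCCCCCCCCCCCCC(OP(=O)(O)OC[C@@H]1C=C[C@H](n2cnc3c(N)ncnc32)O1)C(=O)O` keeps the rest of compound 1 but changes one group on a saturated ring carbon: a group of 10 heavy atoms (5 carbon, 5 nitrogen; one five-membered aromatic ring with 2 hetero atoms, one six-membered aromatic ring with 2 hetero atoms) in place of a group of 9 heavy atoms (5 carbon, 2 nitrogen, 2 oxygen; one six-membered aromatic ring with 2 hetero atoms), on a saturated ring carbon. For the measured compounds named here, no measured pair shows such a swap, so no step beyond the usual scatter is expected in this assay. The expected change is a 1.2-fold lower number from compound 1 to compound 3 (0.09 log units; within the scatter). For compound 3 the estimate is 75000 nM, with an expected range from 25000 nM to 200000 nM.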

Compound 3, half-maximal cytotoxic concentration: 81300 nM
Beside the measured number, compound 3's estimate is 1.1-fold (0.04 log units) below it; the measured number falls inside the stated range.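

In this assay, among the compounds shown here, replacing the single-ring group on the saturated ring carbon next to the ring oxygen with a group of two aromatic rings gives a 1.1-fold lower number from compound 1 to compound 3 (0.06 log units; within the scatter) as the first readable step in this set. The number therefore stays within the scatter when this group is exchanged. No measured property here accounts for that outcome.

Going by these compounds, whether a simple amine or a carboxylic acid at this place would do the same stays open. On these data alone, compound 2 has only a limit of the assay, > 198000 nM, and how the two-ring group behaves with its chain is also open.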